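Trifluoromethoxy for Trifluoromethyl on Two Related Cores

The source may hold more compounds than are shown below. What is called first, only, known or untested is meant among the compounds shown, and "the series" means these compounds.

Compound 1, `CC(O)(CSc1ccccc1C(F)(F)F)C(=O)Nc1cccc(S(F)(F)(F)(F)F)c1`: 21000 nM
Compound 2, `CC(O)(CSc1ccccc1OC(F)(F)F)C(=O)Nc1cccc(S(F)(F)(F)(F)F)c1`: 12600 nM
Compound 3, `CC(O)(COc1cccc(C(F)(F)F)c1)C(=O)Nc1cccc(S(F)(F)(F)(F)F)c1`: 22500 nM

These three compounds were tested in a functional assay on VCaP cells (Homo sapiens) for antiproliferative activity, read by propidium iodide staining, with a stated time of 96 h; on this read-out lower numbers stand for stronger inhibition and higher numbers for weaker inhibition. Compound 2 differs from compound 1 by trifluoromethoxy in place of trifluoromethyl on an aromatic carbon, and this change made a 1.7-fold lower number from compound 1 to compound 2 (0.22 log units; within the scatter). Compound 3 is built on a different core; the difference between the cores of compound 1 and compound 3 is not broken down here. Compound 4, `CC(O)(COc1cccc(OC(F)(F)F)c1)C(=O)Nc1cccc(S(F)(F)(F)(F)F)c1`, has not yet been measured; it differs from compound 3 by trifluoromethoxy in place of trifluoromethyl on an aromatic carbon. Around the place the two changes are not identical: in compound 1 the group sits ortho to a large group, in compound 3 meta to a large group, so this is the same kind of change rather than the same change. Compound 4 is expected to give a step of a 1.6-fold lower number from compound 3 to compound 4 (0.21 log units; within the scatter) in this assay, because the same kind of change gave a 1.7-fold lower number from compound 1 to compound 2 (0.22 log units; within the scatter). Compound 4 is estimated at 14000 nM, between 6000 nM and 35000 nM.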

Compound 4, half-maximal inhibitory concentration: 28600 nM
The estimate for compound 4 lay 2.0-fold (0.31 log units) below the measured number; measured number inside the range.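

In this assay, trifluoromethoxy in place of trifluoromethyl gave a 1.3-fold higher number from compound 3 to compound 4 (0.10 log units; within the scatter), so on this core too the change left the number within the usual scatter. Set beside the earlier step, the result shows no difference between the two cores that exceeds what repeated measurements allow: the same change on two cores in this assay, a 1.7-fold lower number (0.22 log units; within the scatter) from compound 1 to compound 2 and a 1.3-fold higher number (0.10 log units; within the scatter) from compound 3 to compound 4, 2.1-fold (0.33 log units) apart, within the scatter of two such steps. For the compounds shown here, this does not show that the change acts alike on both cores, only that neither step is large enough to tell, and a real but small difference could go unseen.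

The compounds shown carry only trifluoromethyl or trifluoromethoxy on this ring. From the compounds shown here alone, whether a nitrile or an amine there would give a step beyond the scatter on either core remains open.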